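A few compounds are considered here, and "the series" means these few. Any claim that something is new, unique, unknown or untested is made for them only; others in the source may bear on it.

Values in a functional assay on A2780 cells (Homo sapiens) for antiproliferative activity, read by MTT assay, with a stated time of 48 h; a lower number here means a stronger inhibitor of growth, a higher number a weaker inhibitor of growth:
- compound 1 `CCCOC(=O)N1N=C(c2ccccc2)CC1c1cc(OC)c(OC)c(OC)c1`: 10800 nM
- compound 2 `CCCOC(=O)N1N=C(c2ccc(OC)cc2)CC1c1cc(OC)c(OC)c(OC)c1`: 11700 nM

Among the measured compounds shown here, compound 2, at 11700 nM, has the higher of only two numbers, but it lies within the scatter of compound 1, so the pair gives no ranking. The next compound to read is compound 3 `CCCOC(=O)N1N=C(c2cccc(O)c2)CC1c1cc(OC)c(OC)c(OC)c1`, which carries 3-hydroxyphenyl in place of 4-methoxyphenyl on a carbon with a double bond to nitrogen.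

For the measured compounds named here, one measured step bears on this change: a 1.1-fold higher number from compound 1 to compound 2 (0.03 log units; within the scatter), with methoxy in place of hydrogen on an aromatic carbon. That step stays within the scatter, so the methoxy group of compound 2 gives no reason to expect much from its loss. Going by the values given here, no measured compound carries a hydroxy group, so that part of the change is untested and the range has to stay wide. In this assay, no step beyond the scatter is expected, and no direction is favoured with any confidence.

The expected step is a 1.3-fold lower number from compound 2 to compound 3 (0.11 log units; within the scatter).

For compound 3 the estimated value is 9000 nM, with an expected range of 3500 nM to 22000 nM.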

Compound 3, concentration for 50% growth inhibition: 11100 nM
Compound 3: middle estimate off by 1.2-fold (0.09 log units), on the low side; the measured number falls inside the stated range.
By their numbers in this assay, from the lowest: compounds 1, 3 and 2 (each within the scatter of the next).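

In this assay, the change from 4-methoxyphenyl to 3-hydroxyphenyl on the carbon with a double bond to nitrogen gives a 1.1-fold lower number from compound 2 to compound 3 (0.02 log units; within the scatter), and adding hydroxy to the unsubstituted phenyl gives a 1.0-fold higher number from compound 1 to compound 3 (0.01 log units; within the scatter). The hydroxy group brings the first hydrogen-bond donor to this aromatic ring, and phenyl, 4-methoxyphenyl and 3-hydroxyphenyl now all lie within the scatter of one another, so this position shows no separation across these three groups. No supporting data are available to explain this flat reading.

The step between compound 2 and compound 3 alters both the group and its place on the ring, so 3-methoxyphenyl and 4-hydroxyphenyl would be needed to tell those two changes apart. As far as these compounds go, it also remains open whether an amine or a carboxylic acid on this ring, or a longer chain in place of the propoxycarbonyl group, would move the number outside the scatter of these three compounds.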